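Saturating and shortening the lipid tail of a vanillylamide

The compounds below may be only part of what the source reports. "The series", "measured", "known", "first", "only" and "open" are said of these compounds alone.

Compounds measured so far:
Compound 1, `CCCCCCCC/C=C\CCCCCCCCSC[C@H](N)C(=O)NCc1ccc(O)c(OC)c1`, gives 1900 nM.
Compound 2, `CCCCCCCC/C=C\CCCCCCCC(=O)N/N=C/c1ccc(O)c(OC)c1`, gives 120 nM.
Compound 3, `CCCCCCCC/C=C\CCCCCCCCCCCC(=O)NCc1ccc(O)c(OC)c1`, gives 490 nM.

These numbers come from an assay on HEK293 cells for antagonist activity at transient receptor potential cation channel subfamily V member 2 (Rattus norvegicus), read by fluorescence and calcium flux, with a stated time of 5 min; on this read-out higher numbers stand for weaker inhibition and lower numbers for stronger inhibition. Among the three measured compounds, compound 3 holds the middle place: compound 1 sits at a higher number, meaning weaker inhibition, and compound 2 sits at a lower number, meaning stronger inhibition, and both of these gaps lie beyond the usual scatter of this assay. All three share the same vanillyl head group and differ in the long lipid tail and in the link that joins the two.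

Compound 4, `CCCCCCCCCCCCCCCCCCCC(=O)NCc1ccc(O)c(OC)c1`, keeps the amide link and the head group of compound 3 and changes only the far end of the tail: octyl in place of dec-1-en-1-yl on a saturated chain carbon, ten or more bonds along the chain from a carbonyl carbon. The tail thus loses its single double bond and becomes fully saturated and shorter. For the measured compounds named here, no measured pair in this set isolates such a change, so the expectation rests only on the general picture that the two strongest compounds here, compound 2 and compound 3, both carry the unsaturated tail.

The step from compound 3 to compound 4 is therefore expected to go toward a higher number, that is weaker inhibition, by a modest margin, a 2.4-fold higher number from compound 3 to compound 4 (0.39 log units; beyond the scatter). For compound 4 the estimated value in this assay is 1200 nM, with a likely range from 400 nM to 4000 nM.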

Compound 4, half-maximal inhibitory concentration: 3100 nM
Compound 4: the middle estimate sits 2.6-fold (0.41 log units) below what was measured, within the range that was stated.
By their numbers in this assay, from the lowest: compound 2; then compound 3; then compounds 1 and 4 (each within the scatter of the next).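

In this assay, putting octyl in place of dec-1-en-1-yl on a saturated chain carbon, ten or more bonds along the chain from a carbonyl carbon, gives a 6.3-fold higher number from compound 3 to compound 4 (0.80 log units; beyond the scatter) and so means weaker inhibition. The earlier compounds shown here could not show this, since none of them formed a pair differing in one place: the far end of the tail is not a silent stretch of chain, and a change there alone moves the read-out by more than the usual scatter. The change removes the one double bond outside the aromatic ring and also swaps the longer dec-1-en-1-yl group for the shorter octyl group, so this single step cannot divide its effect between the two, and nothing measured here explains it.

A plain decyl group at this place would keep the length of dec-1-en-1-yl without the double bond, and an oct-1-en-1-yl group would keep the double bond on the length of octyl, so either could pull the two parts of the change apart. Going by these compounds, whether a longer chain, or a carboxylic acid at the tail end, would be tolerated at this place also stays open.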